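Cyano for Methyl on Selenium: Expected Loss of Potency

The source may report more compounds than this note shows. Statements on the series, on what has been measured and on what is new or still open speak of the compounds shown alone.

Measured compounds:
compound 1, `C[Se]c1ccc(N(C)c2nc(C3CC3)nc3ccccc23)cc1`: 11 nM
compound 2, `COc1ccc(N(C)c2nc(C)nc3ccccc23)cc1[Se]C`: 3 nM
compound 3, `COc1ccc(N(C)c2nc(C)nc3ccccc23)cc1[Se]C#N`: 73 nM

In a functional assay on LoVo cells (Homo sapiens) for inhibition, read by MTT assay, with a stated time of 48 h (on this read-out lower numbers stand for stronger inhibition and higher numbers for weaker inhibition), compound 2 and compound 3 share one core and differ only in the change (cyano in place of methyl on a selenium). That single change produced the step of a 24-fold higher number from compound 2 to compound 3 (1.39 log units; beyond the scatter), a clear weakening of inhibition that lies far outside the scatter of repeated measurements. Compound 1 sits on a different core; how its core differs from that of compound 2 is not broken down here, so of that pair only the two values themselves can be compared, and compound 1 gives a higher number than compound 2 in this assay.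

Compound 4, `CN(c1ccc([Se]C#N)cc1)c1nc(C2CC2)nc2ccccc12`, is built from compound 1 by the change (cyano in place of methyl on a selenium). The place of the change and the groups that leave and enter are the same as in the step from compound 2 to compound 3, so it is the same change on another core.

The step from compound 1 to compound 4 in this assay is therefore expected to be about a 23-fold higher number from compound 1 to compound 4 (1.36 log units; beyond the scatter), an estimate that rests on the size of the measured step of a 24-fold higher number from compound 2 to compound 3 (1.39 log units; beyond the scatter). On that basis compound 4 is estimated to give roughly 250 nM in this assay, most likely somewhere between 60 nM and 1000 nM; the width of this range reflects that the change has been seen only once, on a different core.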

Compound 4, half-maximal inhibitory concentration: 11 nM
Compound 4: the middle estimate sits 23-fold (1.36 log units) above what was measured; the whole stated range lies above it.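

In this assay the new step reads no change at the digits printed from compound 1 to compound 4 (within the scatter), so the large loss seen on the other core did not appear on the core of compound 1. Set side by side, the two results clearly disagree: the same change on two cores in this assay, a 24-fold higher number (1.39 log units; beyond the scatter) from compound 2 to compound 3 and no change at the digits printed (within the scatter) from compound 1 to compound 4, 24-fold (1.39 log units) apart, beyond the scatter of two such steps. This shows that in this series the size of the step from methyl to cyano on the selenium cannot simply be carried from one core to another, but two pairs cannot show which part of the cores decides the outcome, nor which of the two results is the more typical.

Still open, as far as these compounds go, is whether the same change on a third core would follow the large step or the flat one. Also open, from the compounds shown here alone, is what a longer chain such as ethyl, or a phenyl ring, would give on the selenium of either core in this assay.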